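Swapping an Amidine for a Pyridine: Expected Lipophilicity Shift

This account rests on a few compounds, and the source may have more. Where it says the series, first, only, none or still open, it means among the compounds named here.

Of the compounds shown here, two share one core and have been measured in a physicochemical assay for lipophilicity; on this read-out higher numbers stand for higher lipophilicity and lower numbers for lower lipophilicity. Compound 1, `N=C(N)Nc1cccc(C(=O)NNC(=O)CC(CC(=O)O)c2cc(Cl)cc(Cl)c2)c1`, gives 2.24. Compound 2, `CC(=N)Nc1cccc(C(=O)NNC(=O)CC(CC(=O)O)c2cc(Cl)cc(Cl)c2)c1`, gives 2.55. Among the compounds with values here, the single step between them, a number 0.31 log units higher from compound 1 to compound 2 (beyond the scatter), shows that a small exchange on the amidine end moved the read-out by a modest amount. Within the data shown here, compound 2 therefore stands highest of the two numbers, with compound 1 as its only neighbour, lower by that same step.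

Compound 3, `O=C(O)CC(CC(=O)NNC(=O)c1cccc(Nc2ccccn2)c1)c1cc(Cl)cc(Cl)c1`, has not yet been measured in this assay. It differs from compound 2 in this way: a group of 6 heavy atoms (5 carbon, 1 nitrogen; one six-membered aromatic ring with 1 hetero atom) in place of a group of 3 heavy atoms (2 carbon, 1 nitrogen; no ring), on a nitrogen on an aromatic ring. Among the measured compounds shown here, the only measured step that bears on this position is the one from compound 1 to compound 2, which was modest, and it is not the same exchange. Because a number 0.31 log units higher from compound 1 to compound 2 (beyond the scatter) already pointed upward when a donor-bearing group was trimmed at this spot, an upward step is expected here as well, and a larger one, since a whole aromatic ring enters. Compound 3 is estimated at 3.5, within a range of 2.9 to 4.1. That estimate corresponds to a step of a number 0.95 log units higher from compound 2 to compound 3 (beyond the scatter), expected to lie beyond the scatter.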

Compound 3, partition coefficient: 3.54
Compound 3: the middle estimate sits 0.04 log units below what was measured, within the range that was stated.
By their numbers in this assay, from the lowest: compound 1; then compound 2; then compound 3.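

Placing pyridin-2-yl on the nitrogen on an aromatic ring shows that this position can take a whole aromatic ring in place of an open-chain group, and that in this assay this exchange goes with a much bigger change (a number 0.99 log units higher from compound 2 to compound 3 (beyond the scatter)) than the earlier swap of amino for methyl (a number 0.31 log units higher from compound 1 to compound 2 (beyond the scatter)). Set against the group of the first compound in the series, the same ring gives the only step here printed as large (a number 1.30 log units higher from compound 1 to compound 3 (beyond the scatter)), so the choice of group at this one place spans a wide stretch of the read-out while the rest of the molecule stays the same. Nothing available explains why the number rises with this exchange.

The compounds shown leave open whether the rise follows the ring as a whole or depends on its ring nitrogen, a question that a plain phenyl ring on the same nitrogen would help to separate. They also leave open whether a step of this size would hold if the carboxylic acid of the shared core were replaced by a primary amide.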